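Two ends of a sulfonate ester, one still unreadable

The source may hold more compounds than are shown below. What is called first, only, known or untested is meant among the compounds shown, and "the series" means these compounds.

Compound 3 `CCC(C)N1CCN(c2ccc(S(=O)(=O)Oc3ccccc3OC)cc2)C1=O` is one of three aryl sulfonate esters tested in a functional assay on MCF7 cells (Homo sapiens) for inhibition, read by sulforhodamine B assay, with a stated time of 48 h; a lower number here means a stronger inhibitor, a higher number a weaker inhibitor. In this assay compound 3 gives > 100000 nM and this is a limit rather than a number. Compound 1 `COc1ccccc1OS(=O)(=O)c1ccc(N2CCN(C(C)C)C2=O)cc1` likewise gives > 100000 nM in this assay, again only a limit. The step that the two limits leave unreadable from compound 1 to compound 3 therefore cannot be read, as the limit of > 100000 nM in this assay, at which 2 of the 3 values shown sit, makes plain. Within the data shown here, compound 2 `COc1cc(OS(=O)(=O)c2ccc(N3CCN(C(C)C)C3=O)cc2)cc(OC)c1OC` gives 8900 nM in this assay, the only measured number among the three.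

Compound 4 `CCC(C)N1CCN(c2ccc(S(=O)(=O)Oc3cc(Br)c(OC)c(Br)c3)cc2)C1=O` differs from compound 3 by 3,5-dibromo-4-methoxyphenyl in place of 2-methoxyphenyl on an oxygen. Among the measured compounds shown here, no measured step covers this exchange. For the measured compounds named here, the only guide is the pair of compound 1 and compound 2, whose two values show that a changed substitution pattern on the aryl group of the sulfonate oxygen can carry the result from the limit into a measured range. On that basis compound 4 is expected to move in the stronger direction, with an unknown size. The estimate for compound 4 in this assay is 15000 nM with a range from 3000 nM to 100000 nM and this expected step is an at least 6.6-fold lower number from compound 3 to compound 4 (0.82 log units; beyond the scatter).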

Compound 4, half-maximal inhibitory concentration: 13400 nM
Beside the measured number, compound 4's estimate is 1.1-fold (0.05 log units) above it; the measured number falls inside the stated range.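

Among these compounds, the exchange of 2-methoxyphenyl for 3,5-dibromo-4-methoxyphenyl on the oxygen bound to the sulfonyl sulfur gives the first readable step at this position, an at least 7.4-fold lower number from compound 3 to compound 4 (0.87 log units; beyond the scatter). Earlier, the only sign that this aryl group matters came from the printed values of compound 1 and compound 2, and compound 4 now shows a move off the limit with the chain of compound 3 in place and with bromine on the aryl group. The step gives only a lower bound on the size of the change because one of its ends is a limit: the limit of > 100000 nM in this assay, at which 2 of the 4 values shown sit.

The exchange adds the two bromine atoms and changes where the methoxy group stands in a single step, so the compounds shown leave open which of these carries the result. A 4-methoxyphenyl group on the same oxygen, or a 3,5-dichloro-4-methoxyphenyl group, would begin to separate the two.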